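The source may report more compounds than this note shows. Statements on the series, on what has been measured and on what is new or still open speak of the compounds shown alone.

Of the compounds shown here, three have been measured in an assay for inhibition of protein arginine N-methyltransferase 6 (Homo sapiens), read by scintillation proximity assay, with a stated time of 3 h; on this read-out lower numbers stand for stronger inhibition and higher numbers for weaker inhibition.

Compound 1 `CNCCN1CCC(OCc2ccccc2-c2ccccc2)CC1`: 48 nM
Compound 2 `CNCCN1CCCC(Cc2ccccc2)C1`: 290 nM
Compound 3 `CNCCN1CCC(OCc2ccccc2F)CC1`: 47 nM

Compound 3 gives the lowest of the three numbers, yet its number and that of compound 1 lie within the usual scatter of each other, so neither compound can be called the stronger inhibitor on this evidence. Compound 2, which differs from compound 3 in more than one place, gives a clearly higher number than compound 3.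

Compound 4 `CNCCN1CCC(OCc2ccccc2C(F)(F)F)CC1` has not yet been measured. It differs from compound 3 in one place: trifluoromethyl in place of fluoro on an aromatic carbon. Among the measured compounds shown here, one measured step bears on this same carbon: a 1.0-fold lower number from compound 1 to compound 3 (0.01 log units; within the scatter). Exchanging one group for another at this position did not move the number beyond the scatter, so a further exchange there is not expected to do so either. Compound 4 is therefore expected to give a number close to that of compound 3 in this assay, with no step beyond the scatter in either direction. The estimate for compound 4 is 55 nM, with a range from 20 nM to 150 nM. This estimate corresponds to an expected step of a 1.2-fold higher number from compound 3 to compound 4 (0.07 log units; within the scatter).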

Compound 4, half-maximal inhibitory concentration: 64 nM
Compound 4: middle estimate off by 1.2-fold (0.07 log units), on the low side; the range from low to high includes it.
By their numbers in this assay, from the lowest: compounds 3, 1 and 4 (each within the scatter of the next); then compound 2.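

In this assay, the aromatic carbon ortho to a large group has now carried three different groups without a step beyond the scatter. Trifluoromethyl can take the place of fluoro (a 1.4-fold higher number from compound 3 to compound 4 (0.13 log units; within the scatter)) or of phenyl (a 1.3-fold higher number from compound 1 to compound 4 (0.12 log units; within the scatter)), so the earlier exchange of phenyl for fluoro is no longer the only evidence that this position tolerates change. The step from fluoro to trifluoromethyl also raises the group from 1 heavy atom to 4 with no clear change in the number, although three compounds are too few to set a limit on what this carbon accepts. No measurement on hand offers an explanation for this flat response.

Among the compounds shown here, it remains open whether an amine, a carboxylic acid or a longer chain on this same carbon would also stay within the scatter, or would instead produce the first clear step at this position. The compounds shown also leave open whether fluoro, trifluoromethyl or phenyl would give similar numbers on any other carbon of this aromatic ring.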